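A few compounds are considered here, and "the series" means these few. Any claim that something is new, unique, unknown or untested is made for them only; others in the source may bear on it.

Compound 1, `COc1ccc(/C=N\NC(=S)NC(C)(C)CCC[C@](C)(O)[C@@H]2CC=C(C)CC2)cc1`, gives 5100 nM in a functional assay on NCI-H460 cells (Homo sapiens) for cytotoxicity, read by sulforhodamine B assay; on this read-out lower numbers stand for stronger inhibition of growth and higher numbers for weaker inhibition of growth.
Compound 2, `CC1=CC[C@@H]([C@@](C)(O)CCCC(C)(C)NC(=S)N/N=C\c2cccc([N+](=O)[O-])c2)CC1`, gives 8290 nM.
Compound 3, `CC1=CC[C@@H]([C@@](C)(O)CCCC(C)(C)NC(=S)N/N=C\c2ccc([N+](=O)[O-])cc2)CC1`, gives 10100 nM.

Compound 1 sits at the low end of these three numbers, but only narrowly: the step of a 1.6-fold higher number from compound 1 to compound 2 (0.21 log units; within the scatter) and the step of a 2.0-fold higher number from compound 1 to compound 3 (0.30 log units; within the scatter) both lie within the scatter, so the three compounds cannot be told apart on this read-out. Compound 4, `CC1=CC[C@@H]([C@@](C)(O)CCCC(C)(C)NC(=S)N/N=C\c2ccc(Cl)cc2)CC1`, has not been measured yet. It differs from compound 1 in one place: chloro in place of methoxy on an aromatic carbon.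

Going by the values given here, no measured step exchanges methoxy for chloro, so nothing bears on this change directly. The closest guide is the step of a 2.0-fold higher number from compound 1 to compound 3 (0.30 log units; within the scatter), where the same methoxy was exchanged for a different group on the same aromatic carbon, and the step of a 1.2-fold higher number from compound 2 to compound 3 (0.09 log units; within the scatter), where the group was moved around the ring; both stayed within the scatter. The three measured compounds thus show that the group on this ring made little difference among them.

For compound 4 the expectation is therefore a number close to that of compound 1, with the step of a 1.2-fold higher number from compound 1 to compound 4 (0.07 log units; within the scatter) expected to lie within the scatter. Compound 4 is estimated at 6000 nM, within a range of 2500 nM to 15000 nM.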

Compound 4, concentration for 50% growth inhibition: 8720 nM
Compound 4: the middle estimate sits 1.5-fold (0.16 log units) below what was measured; the measured number falls inside the stated range.
By their numbers in this assay, from the lowest: compounds 1, 2, 4 and 3 (each within the scatter of the next).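

In this assay, replacing methoxy with chloro on this aromatic carbon swaps two heavy atoms and a hydrogen-bond acceptor for one heavy atom and no acceptor, and the result (a 1.7-fold higher number from compound 1 to compound 4 (0.23 log units; within the scatter)) shows that this change also stays within the scatter. Chloro in place of nitro at the same ring position (a 1.2-fold lower number from compound 3 to compound 4 (0.06 log units; within the scatter)) and 4-chlorophenyl in place of 3-nitrophenyl (a 1.1-fold higher number from compound 2 to compound 4 (0.02 log units; within the scatter)) stay within it too, so a third kind of group joins methoxy and nitro and all four compounds remain indistinguishable on this read-out. Nothing measured here gives a reason for this flat picture.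

Going by these compounds, all four compounds carry a single methoxy, nitro or chloro group on the ring, so it remains open whether an amine, a carboxylic acid or a longer chain there would give a number beyond the scatter. On these data alone, it also remains open whether changes elsewhere in the shared core would matter more than changes on this ring.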